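Pentafluoroethyl for Nitro: Expecting Compound 4

The source may report more compounds than this note shows. Statements on the series, on what has been measured and on what is new or still open speak of the compounds shown alone.

Measured compounds in a functional assay (aorta) with Rattus norvegicus as the target; a lower number here means that less compound is needed, a higher number that more compound is needed for the effect:
compound 1 `O=C1CCCN1[C@@H]1c2cc([N+](=O)[O-])ccc2OC(CF)(CF)[C@H]1O` — 24 nM
compound 2 `O=C1CCCN1[C@@H]1c2cc(C(F)(F)C(F)(F)F)ccc2OC(CF)(CF)[C@H]1O` — 6.31 nM
compound 3 `O=c1ccccn1[C@@H]1c2cc([N+](=O)[O-])ccc2OC(CF)(CF)[C@H]1O` — 28.8 nM

Compound 3 differs from compound 1 in the substituent on the saturated ring carbon: a group of 7 heavy atoms (5 carbon, 1 nitrogen, 1 oxygen; one six-membered aromatic ring with 1 hetero atom) in place of a group of 6 heavy atoms (4 carbon, 1 nitrogen, 1 oxygen; one five-membered non-aromatic ring with 1 hetero atom), on a saturated ring carbon This exchange gave a 1.2-fold higher number from compound 1 to compound 3 (0.08 log units; within the scatter), so the two cores behave alike in this assay. On the core of compound 1, the aromatic substituent exchange 1,1,2,2,2-pentafluoroethyl in place of nitro on an aromatic carbon gave a 3.8-fold lower number from compound 1 to compound 2 (0.58 log units; beyond the scatter).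

Compound 4 `O=c1ccccn1[C@@H]1c2cc(C(F)(F)C(F)(F)F)ccc2OC(CF)(CF)[C@H]1O` carries the same change on the core of compound 3: 1,1,2,2,2-pentafluoroethyl in place of nitro on an aromatic carbon The place is the same in both cases, so this is the same change. Since compound 1 and compound 3 lie within the scatter of one another, the step is expected to carry over, giving an estimated 3.6-fold lower number from compound 3 to compound 4 (0.56 log units; beyond the scatter). Compound 4 is therefore expected to give about 8 nM, estimated between 3 nM and 20 nM.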

Compound 4, half-maximal effective concentration: 12 nM
Estimate against measurement, compound 4: 1.5-fold (0.18 log units) below; the range from low to high includes it.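

In this assay, 1,1,2,2,2-pentafluoroethyl in place of nitro on the core of compound 3 gave a 2.4-fold lower number from compound 3 to compound 4 (0.38 log units; beyond the scatter), and this step agrees with the one on the core of compound 1: the same change on two cores in this assay, a 3.8-fold lower number (0.58 log units; beyond the scatter) from compound 1 to compound 2 and a 2.4-fold lower number (0.38 log units; beyond the scatter) from compound 3 to compound 4, 1.6-fold (0.20 log units) apart, within the scatter of two such steps. The exchange on the saturated ring carbon, which gave a 1.9-fold higher number from compound 2 to compound 4 (0.28 log units; within the scatter), likewise matches its earlier counterpart: the same change on two cores in this assay, a 1.2-fold higher number (0.08 log units; within the scatter) from compound 1 to compound 3 and a 1.9-fold higher number (0.28 log units; within the scatter) from compound 2 to compound 4, 1.6-fold (0.20 log units) apart, within the scatter of two such steps. Within these four compounds, the aromatic substituent change therefore carried over from one core to the other, but two cores cannot show that it would hold on other cores, nor do they explain why it carried over.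

The compounds shown leave open whether trifluoromethyl or nitrile on the same aromatic carbon would behave like 1,1,2,2,2-pentafluoroethyl. They also leave open whether an open-chain amide on the saturated ring carbon would match the two ring groups.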